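Allyl to cyclopentyl on the shared core

The source may report more compounds than this note shows. Statements on the series, on what has been measured and on what is new or still open speak of the compounds shown alone.

Measured so far in a functional assay on HCT-116 cells (Homo sapiens) for cytotoxicity, read by MTT assay, with a stated time of 48 h; on this read-out lower numbers stand for stronger inhibition of growth and higher numbers for weaker inhibition of growth
compound 1 `Fc1ccccc1-c1nc2cc(Cl)c(Cl)cc2[nH]1` gives 56500 nM
compound 2 `C=CCn1c(C(F)(F)F)nc2cc(Cl)c(Cl)cc21` gives 89200 nM
compound 3 `Nc1ccccc1Cn1c(C(F)(F)F)nc2cc(Cl)c(Cl)cc21` gives 26100 nM

Compound 2 and compound 1 lie within the scatter of each other at the upper end of these numbers, and compound 3 sits lower. Compound 4 `FC(F)(F)c1nc2cc(Cl)c(Cl)cc2n1C1CCCC1` carries cyclopentyl in place of allyl on an aromatic nitrogen as its one difference, cyclopentyl in place of allyl on an aromatic nitrogen. Within the data shown here, the only measured step on that substituent (a 3.4-fold lower number from compound 2 to compound 3 (0.53 log units; beyond the scatter)) is modest and brings in a different group, so it is a loose guide. In this assay a small move toward a lower number is expected (a 1.5-fold lower number from compound 2 to compound 4 (0.17 log units; within the scatter)), probably not beyond the scatter. For compound 4 the value is estimated at 60000 nM (expected range 25000 nM to 120000 nM).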

Compound 4, concentration for 50% growth inhibition: 22000 nM
Beside the measured number, compound 4's estimate is 2.7-fold (0.44 log units) above it; measured number below the stated range.
By their numbers in this assay, from the lowest: compounds 4 and 3 (each within the scatter of the next); then compounds 1 and 2 (each within the scatter of the next).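

In this assay, cyclopentyl in place of allyl on an aromatic nitrogen gives a 4.1-fold lower number from compound 2 to compound 4 (0.61 log units; beyond the scatter), so a saturated carbon ring at this position also lowers the number. The 2-aminophenyl group is therefore not needed for that drop: compound 3 at 26100 nM and compound 4 at 22000 nM lie within the scatter of each other. No supporting data bear on what lies behind the step.

The compounds shown leave open whether the ring itself or the larger carbon count goes with the lower number. A longer open carbon chain or a cyclohexyl ring on the same nitrogen would separate the two.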